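The source may report more compounds than this note shows. Statements on the series, on what has been measured and on what is new or still open speak of the compounds shown alone.

Measured in a functional assay on MDA-MB-231 cells (Homo sapiens) for antiproliferative activity, read by MTT assay, with a stated time of 96 h; on this read-out lower numbers stand for stronger inhibition and higher numbers for weaker inhibition:
Compound 1 `CC(C)=CCC/C(C)=C/CC/C(C)=C/CC[C@]1(C)CCc2cc(OC(=O)NS(=O)(=O)c3ccc(C)cc3)cc(C)c2O1`: 6600 nM
Compound 2 `CC(C)=CCC/C(C)=C/CC/C(C)=C/CC[C@]1(C)CCc2cc(OC(=O)Nc3ccccc3)c(C)c(C)c2O1`: > 10000 nM (a limit)
Compound 3 `CC(C)=CCC/C(C)=C/CC/C(C)=C/CC[C@]1(C)CCc2cc(OC(=O)NS(=O)(=O)c3ccccc3)cc(C)c2O1`: > 10000 nM (a limit)

In this assay compound 3 stands at > 10000 nM, which is a limit and not a number. Compound 4 `CC(C)=CCC/C(C)=C/CC/C(C)=C/CC[C@]1(C)CCc2cc(OC(=O)Nc3ccccc3)cc(C)c2O1` keeps the core of compound 3 and carries phenyl in place of phenylsulfonyl on an amide-type nitrogen. For the measured compounds named here, no measured step changes that place. Going by the values given here, the one step available, an at least 1.5-fold higher number from compound 1 to compound 3 (0.18 log units; that floor lies within the scatter), concerns hydrogen in place of methyl on an aromatic carbon, and its floor lies within the scatter, so it offers little guidance on size. The nearest comparison is compound 2, which also carries phenyl on the amide-type nitrogen, though its core is not identical. Compound 2 gives > 10000 nM, again a limit. The series is dominated by the limit of > 10000 nM in this assay, at which 2 of the 3 values shown sit. No change beyond the scatter is therefore expected, and the estimated step is a number no higher from compound 3 to compound 4 (the limit leaves the size open). For compound 4 the estimated value is 10000 nM, with an expected range from 4000 nM to 25000 nM.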

Compound 4, half-maximal inhibitory concentration: > 10000 nM
Compound 4: a limit, no number (the forecaster's own chance of this, stated with the estimate: 60%); the middle value lies on the limit itself.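

In this assay the amide-type nitrogen on the core of compound 3 now has a change of its own: with phenyl in place of phenylsulfonyl, compound 4 remains at a limit, as compound 3 does, so the steps from compound 3 to compound 4 and from compound 2 to compound 4 cannot be read. For the compounds shown here, the one readable step, an at least 1.5-fold higher number from compound 1 to compound 4 (0.18 log units; that floor lies within the scatter), exchanges (4-methylphenyl)sulfonyl for phenyl and gives no evidence of a change beyond the scatter. Only compound 1 carries a number, and the rest of the series offers only this: the limit of > 10000 nM in this assay, at which 3 of the 4 values shown sit.

As far as these compounds go, it remains open how far either group on this nitrogen lies past the limit. From the compounds shown here alone, it is also open whether a benzyl or an acetyl group at this place would give a readable number on the core of compound 3.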